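ROCK2 series: amino in place of ethyl on the benzamide side

The source may hold more compounds than are shown below. What is called first, only, known or untested is meant among the compounds shown, and "the series" means these compounds.

Compound 3 `CCCc1ccc(C(=O)Nc2cccc(NC(=O)COc3ccc4c(=O)ccoc4c3)c2)cc1`: 14 nM
Compound 2 `CN(C)c1ccc(C(=O)Nc2cccc(NC(=O)COc3ccc4c(c3)OCCC4=O)c2)cc1`: 85 nM
Compound 1 `COc1cccc(OCC(=O)Nc2cccc(NC(=O)c3ccc(N(C)C)cc3)c2)c1`: 5740 nM

In an assay on isolated protein for inhibition of Rho-associated protein kinase 2 (Homo sapiens), read by scintillation counting, radiometric assay and 33P incorporation, with a stated time of 40 min, in the presence of a further agent that is not named here (on this read-out lower numbers stand for stronger inhibition and higher numbers for weaker inhibition), compound 3 gives the lowest number of the three, compound 2 the next, compound 1 the highest. Within the data shown here, the one single-point step recorded, a 68-fold lower number from compound 1 to compound 2 (1.83 log units; beyond the scatter), lies on the ether side of the shared core and does not touch the benzamide end. Among the measured compounds shown here, compound 2 and compound 3 differ in two places at once, so their values say only that the pair of changes together moves the number down; the two parts cannot be separated.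

Compound 4 `NCc1ccc(C(=O)Nc2cccc(NC(=O)COc3ccc4c(=O)ccoc4c3)c2)cc1` is the next step from compound 3: amino in place of ethyl on a saturated chain carbon bound to an aromatic carbon. For the measured compounds named here, no measured step bears on this change; the benzamide aryl substituent has not yet been varied on its own within this set. The expectation therefore rests on compound 3 alone, with wide bounds. The step from compound 3 is estimated as a 1.4-fold higher number from compound 3 to compound 4 (0.15 log units; within the scatter), no clear direction beyond the scatter being defensible. Compound 4 is accordingly estimated at 20 nM, with a range from 4 nM to 100 nM.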

Compound 4, half-maximal inhibitory concentration: 66 nM
Estimate against measurement, compound 4: 3.3-fold (0.52 log units) below, within the range that was stated.
By their numbers in this assay, from the lowest: compound 3; then compounds 4 and 2 (each within the scatter of the next); then compound 1.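

In this assay, among these compounds, the change of propyl to aminomethyl gives a 4.7-fold higher number from compound 3 to compound 4 (0.67 log units; beyond the scatter), the first single-place reading at the benzamide end of the series: the number at this substituent responds to a change made on its own, and here it goes up. The step is smaller than a 68-fold lower number from compound 1 to compound 2 (1.83 log units; beyond the scatter) on the ether side of the shared core, and compound 4 stays at 66 nM, so among these compounds an amino group on this saturated chain carbon costs less than the change from the 3-methoxyphenyl-type ether group costs on the other side. Nothing at hand accounts for the rise in the number.

From the compounds shown here alone, it remains open whether the step belongs to the amine itself or to the shorter chain, which a hydroxymethyl group, a longer aminopropyl chain or a carboxylic acid on the same carbon would help to separate. Going by these compounds, it also remains open how much of the gap between compound 2 and compound 3 comes from the benzamide end and how much from the ether side.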